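The compounds below may be only part of what the source reports. "The series", "measured", "known", "first", "only" and "open" are said of these compounds alone.

Compound 1 `N=C(NCCCc1c[nH]cn1)NCCC(c1ccccc1)c1ccccn1` is the point of departure. Among the compounds with values here, in a functional assay on muscle tissue for agonist activity at histamine H2 receptor (Cavia porcellus) (on this read-out higher numbers stand for larger maximal responses and lower numbers for smaller maximal responses), compound 1 gives 0.7, the highest of the two numbers measured so far. Within the data shown here, compound 2 `N=C(NCCCc1c[nH]cn1)NCCC(c1cccc(F)c1)c1ccccn1` differs from it in one place, and in this assay compound 2 gives 0.5; the step a number 0.20 lower from compound 1 to compound 2 (beyond the scatter) is the only measured step that bears on the change now considered.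

Compound 3 `N=C(NCCCc1c[nH]cn1)NCCC(c1cc(F)cc(F)c1)c1ccccn1` is not yet measured. It differs from compound 1 as follows: 3,5-difluorophenyl in place of phenyl on a saturated chain carbon bound to an aromatic carbon and a saturated chain carbon. Among the measured compounds shown here, the single measured step, from one fluorine to none, is modest but beyond the scatter, and compound 3 carries two fluorines where compound 2 carries one. A further fall in this assay is therefore expected, of a size at least comparable to that step. Compound 3 is estimated to give 0.35, between 0.15 and 0.55, which means an expected step of a number 0.35 lower from compound 1 to compound 3 (beyond the scatter).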

Compound 3, intrinsic activity: the largest response reached, as a fraction of the reference agonist's: 0.8
The estimate for compound 3 lay 0.45 below the measured number; the measured number lies above the stated range.
By their numbers in this assay, from the lowest: compound 2; then compounds 1 and 3 (each within the scatter of the next).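

The effect of fluorine at this position does not simply add up: the second fluorine gives a number 0.30 higher from compound 2 to compound 3 (beyond the scatter) in this assay, so the fall seen with one fluorine does not continue. With a number 0.10 higher from compound 1 to compound 3 (within the scatter), the 3,5-difluorophenyl group on this saturated chain carbon is tolerated about as well as phenyl in this assay, and compound 2 alone stands apart among the three compounds. Nothing available here accounts for this reversal.

The compounds shown leave open whether chloro or methoxy groups in place of the two fluorines would keep a response like that of compound 3. They also leave open whether the 3,5-difluorophenyl group would hold up in the same way with a longer chain linking it to the rest of the core.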